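Bromine on the aromatic ring of a chromene hydantoin

The source may report more compounds than this note shows. Statements on the series, on what has been measured and on what is new or still open speak of the compounds shown alone.

Compound 1 `O=C1NC(=O)/C(=C/C2=Cc3ccccc3OC2)N1`: 8100 nM in a functional assay on MCF7 cells (Homo sapiens) for antiproliferative activity, read by MTT assay, with a stated time of 72 h; a lower number here means a stronger inhibitor, a higher number a weaker inhibitor
Compound 2 `O=C(O)CN1C(=O)/C(=C/C2=Cc3ccccc3OC2)SC1=S`: > 100000 nM in this assay

Within the data shown here, only two compounds have been measured so far. In this assay, among the measured compounds shown here, compound 1 gives 8100 nM, the only numerical reading available. For compound 2 the value reported is > 100000 nM, which is a limit of the assay rather than a number. Compound 1 therefore stands alone as the measured point, set against the limit of > 100000 nM in this assay, at which 1 of the 2 values shown sits, for the other entry.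

The next compound, compound 3 `O=C1NC(=O)/C(=C/C2=Cc3cc(Br)ccc3OC2)N1`, keeps the whole core of compound 1 and differs in one place: bromo in place of hydrogen on an aromatic carbon. For the measured compounds named here, no measured pair of this kind is available to anchor how large such a change tends to be. With bromo in place of hydrogen on an aromatic carbon, a modest gain in potency is expected, at most a small step beyond the usual scatter, so the step is estimated as a 1.6-fold lower number from compound 1 to compound 3 (0.21 log units; within the scatter). Compound 3 is thus expected to give about 5000 nM, with a likely range from 1500 nM to 20000 nM.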

Compound 3, half-maximal inhibitory concentration: 51000 nM
Estimate against measurement, compound 3: 10-fold (1.01 log units) below; the measured number lies above the stated range.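

Placing a single bromo on this aromatic carbon, meta to a fused ring and para to a fused ring, weakens the compound in this assay, giving a 6.3-fold higher number from compound 1 to compound 3 (0.80 log units; beyond the scatter). This carbon of the shared core is therefore not indifferent to what it carries, since one added heavy atom is enough to produce a change larger than ordinary assay noise. Compound 3 still gives a number, whereas the reading for compound 2 is a limit of the assay, not a number: the limit of > 100000 nM in this assay, at which 1 of the 3 values shown sits.

A single pair cannot show why potency falls, or whether the loss belongs to bromine itself or to any group at this carbon. A smaller fluoro or chloro, a methoxy or an amine at the same place would help separate these possibilities, as would bromo on another carbon of the ring.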